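Swapping an Amine Substituent for an Amide in a Sigma Ligand

This account rests on a few compounds, and the source may have more. Where it says the series, first, only, none or still open, it means among the compounds named here.

Measured so far:
compound 1, `OC(Cc1ccccc1)CN1CCC(NCCSC(c2ccc(F)cc2)c2ccc(F)cc2)CC1`: 309 nM
compound 2, `[O-][S+](CCNC1CCN(CC(O)Cc2ccccc2)CC1)C(c1ccc(F)cc1)c1ccc(F)cc1`: 351 nM

In an assay on membranes from Cortex for displacement of a labelled ligand from Sigma non-opioid intracellular receptor 1 (Cavia porcellus), read by scintillation counting, with a stated time of 120 min (a higher number here means a weaker inhibitor, a lower number a stronger inhibitor), compound 1 gives 309 nM, and compound 2 gives 351 nM in this assay. The two numbers sit so close together that the usual scatter of this measurement covers the gap, so neither compound is set apart from the other.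

Compound 3, `O=C(c1ccc(F)cc1F)N1CCC(NCCSC(c2ccc(F)cc2)c2ccc(F)cc2)CC1`, has not yet been measured in this assay. It differs from compound 1 in one place: (2,4-difluorophenyl)carbonyl in place of 2-hydroxy-3-phenylpropyl on an amine nitrogen in a ring. The group that leaves carries a hydrogen-bond donor; the group that enters carries none.

Going by the values given here, no pair of measured compounds shares this kind of change, so the size of the step is uncertain. A weakening beyond the scatter is expected, and the estimated step is a 2.9-fold higher number from compound 1 to compound 3 (0.46 log units; beyond the scatter). Compound 3 is expected to give about 900 nM in this assay, within a range of 250 nM to 3500 nM.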

Compound 3, inhibition constant: 20.6 nM
For compound 3 the middle estimate is 44-fold (1.64 log units) above the measured one; the measured number lies below the stated range.
By their numbers in this assay, from the lowest: compound 3; then compounds 1 and 2 (each within the scatter of the next).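

On the amine nitrogen in the six-membered ring, putting (2,4-difluorophenyl)carbonyl in place of 2-hydroxy-3-phenylpropyl gives a 15-fold lower number from compound 1 to compound 3 (1.18 log units; beyond the scatter) in this assay, a large step. Going by these compounds alone, compounds 1 and 2 carry the same group on this nitrogen, so only this new step shows how strongly the number can respond to a change there, and it shows that the hydrogen-bond donor of the group that leaves is not needed for a low number. Nothing at hand explains why the number falls so far.

The step combines several changes, so the share of the carbonyl and the share of the two fluorines cannot be separated; a plain benzoyl group or a 2,4-difluorobenzyl group on the same nitrogen would pull them apart. From the compounds shown here alone, whether the same gain would appear with the sulfoxide of compound 2 also remains open.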